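Iodo for Isopropyl, Tried on a Second Core

The compounds below may be only part of what the source reports. "The series", "measured", "known", "first", "only" and "open" are said of these compounds alone.

Of the compounds shown here, three have been measured so far: compound 1 `CCCCCC(=O)Nc1ccc(S(=O)(=O)Oc2ccccc2C(C)C)cc1`, compound 2 `CCCCCC(=O)Nc1ccc(S(=O)(=O)Oc2ccccc2I)cc1` and compound 3 `CC(C)C(=O)Nc1ccc(S(=O)(=O)Oc2ccccc2C(C)C)cc1`. In a functional assay on HT-29 cells (Homo sapiens) for antiproliferative activity, read by sulforhodamine B assay, with a stated time of 48 h (a lower number here means a stronger inhibitor, a higher number a weaker inhibitor), compound 1 gives 6400 nM, compound 2 gives 13000 nM and compound 3 gives 14000 nM. Compound 2 differs from compound 1 by iodo in place of isopropyl on an aromatic carbon, and this change gives a 2.0-fold higher number from compound 1 to compound 2 (0.31 log units; beyond the scatter). The two cores themselves differ as compound 3 differs from compound 1, by isopropyl in place of pentyl on a carbonyl carbon, and that difference gives a 2.2-fold higher number from compound 1 to compound 3 (0.34 log units; beyond the scatter). Compound 3 stands with the highest of the three numbers, though its gap to compound 2 lies within the scatter.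

Compound 4 `CC(C)C(=O)Nc1ccc(S(=O)(=O)Oc2ccccc2I)cc1` has not yet been measured. It differs from compound 3 by iodo in place of isopropyl on an aromatic carbon, the same change as from compound 1 to compound 2, at the same place. For the measured compounds named here, the step expected in this assay is a 2.0-fold higher number from compound 3 to compound 4 (0.30 log units; within the scatter), taken to match in size the measured step because a 2.0-fold higher number from compound 1 to compound 2 (0.31 log units; beyond the scatter) is the only measured instance of the change. Compound 4 is therefore estimated at 28000 nM, with a likely range from 13000 nM to 60000 nM.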

Compound 4, half-maximal inhibitory concentration: 13000 nM
Compound 4: middle estimate off by 2.2-fold (0.33 log units), on the high side; the range from low to high includes it.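

In this assay, iodo in place of isopropyl on an aromatic carbon gives a 1.1-fold lower number from compound 3 to compound 4 (0.03 log units; within the scatter), and the two instances of this change cannot be told apart: the same change on two cores in this assay, a 2.0-fold higher number (0.31 log units; beyond the scatter) from compound 1 to compound 2 and a 1.1-fold lower number (0.03 log units; within the scatter) from compound 3 to compound 4, 2.2-fold (0.34 log units) apart, within the scatter of two such steps. Isopropyl in place of pentyl on a carbonyl carbon gives no change at the digits printed from compound 2 to compound 4 (within the scatter), and this change also shows no difference between its two instances: the same change on two cores in this assay, a 2.2-fold higher number (0.34 log units; beyond the scatter) from compound 1 to compound 3 and no change at the digits printed (within the scatter) from compound 2 to compound 4, 2.2-fold (0.34 log units) apart, within the scatter of two such steps. Neither change is thus shown to behave differently on the two cores, but that does not prove that either carries over unchanged, as each comparison rests on only two steps, and both new steps lie within the scatter while both earlier ones lie beyond it.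

The compounds shown leave open how a chloro or methoxy group would compare with iodo and isopropyl on that aromatic carbon. They also leave open whether a longer chain than pentyl on the carbonyl carbon, such as octyl, would shift the number in either direction.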